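The source may report more compounds than this note shows. Statements on the series, on what has been measured and on what is new or still open speak of the compounds shown alone.

Measured compounds:
compound 1 `CC(C)CN1CCc2nc(C#Cc3ccccc3)sc2C1`: > 10000 nM
compound 2 `Fc1cccc(C#Cc2nc3c(s2)CN(C2CCOC2)CC3)c1`: > 10000 nM

The study tracks the response of a shared core in an assay on HEK293 cells for positive allosteric modulation of metabotropic glutamate receptor 5 (Homo sapiens), read by FLIPR, with a stated time of 1 h; on this read-out higher numbers stand for an effect only at larger amounts of compound and lower numbers for an effect already at smaller amounts. Compound 1 does not reach a measurable number in this assay; its result of > 10000 nM is a limit of the assay, not a value. Compound 2 likewise reaches only a limit in this assay, > 10000 nM. Among the measured compounds shown here, both results thus sit at the limit of > 10000 nM in this assay, at which 2 of the 2 values shown sit, so neither compound gives a point on the scale against which the next one could be set, and no step between measured compounds can be drawn.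

Compound 3 `O=C(C1CC(F)C1)N1CCc2nc(C#Cc3ccccc3)sc2C1` is not yet measured in this assay. It differs from compound 1 at one place: (3-fluorocyclobutyl)carbonyl in place of isobutyl on an amine nitrogen in a ring. With compound 1 giving only a limit, the step from compound 1 to compound 3 can only be estimated downward from that limit or not at all, and the estimated step is an at least 3.3-fold lower number from compound 1 to compound 3 (0.52 log units; beyond the scatter). On this basis compound 3 is expected to give about 3000 nM in this assay, within a range from 300 nM to 20000 nM, with a real chance that it, too, returns only a limit.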

Compound 3, half-maximal effective concentration: 85 nM
Compound 3: the middle estimate sits 35-fold (1.55 log units) above what was measured, and the stated range ends above it.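

In this assay, (3-fluorocyclobutyl)carbonyl in place of isobutyl on an amine nitrogen in a ring gives an at least 110-fold lower number from compound 1 to compound 3 (2.07 log units; beyond the scatter), a large step and the first that can be read in this series. Compound 1 and compound 2 stay at a limit, which is not a number, so until now the compounds gave no sign that any change to the shared core could bring a measurable result: the limit of > 10000 nM in this assay, at which 2 of the 3 values shown sit. Compound 3 shows that this nitrogen is a place where one change can carry the core from that limit to a measured value, and that the entering group, with its carbonyl, its four-membered ring, its fluorine and its hydrogen-bond acceptor, is tolerated there.

The single step changes all of these features together, so the compounds shown do not tell whether the carbonyl, the ring or the fluorine carries the effect. Going by these compounds, it remains open how a plain cyclobutylcarbonyl without the fluorine, a simple acetyl or a longer acyl chain would read at the same nitrogen.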